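Hydroxy to dimethylamino in the growth inhibition series

The source may hold more compounds than are shown below. What is called first, only, known or untested is meant among the compounds shown, and "the series" means these compounds.

In a functional assay on MOLT-4 cells (Homo sapiens) for inhibition (on this read-out higher numbers stand for weaker inhibition of growth and lower numbers for stronger inhibition of growth), compound 1 `NS(=O)(=O)c1ccc(/C=C/c2ccc(F)cc2)cc1` gives 12900 nM and compound 2 `NS(=O)(=O)c1ccc(/C=C/c2ccc(O)cc2)cc1` gives 22600 nM. Within the data shown here, compound 2 therefore stands within the scatter of compound 1, the only other measured compound, and the two values cannot be ranked.

The next structure is compound 3 `CN(C)c1ccc(/C=C/c2ccc(S(N)(=O)=O)cc2)cc1`, with dimethylamino in place of hydroxy on an aromatic carbon, para to a large group: dimethylamino in place of hydroxy on an aromatic carbon.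

Among the measured compounds shown here, only one measured step bears on this change: a 1.8-fold higher number from compound 1 to compound 2 (0.24 log units; within the scatter). It exchanges fluoro for hydroxy at the same place and stays within the scatter. For the measured compounds named here, no measured compound carries dimethylamino, so the evidence is indirect and gives no direction for the new group. Going by compound 1 and compound 2, whose step is a 1.8-fold higher number from compound 1 to compound 2 (0.24 log units; within the scatter), no shift beyond the scatter is expected in this assay, though the wide range below allows for the untested group.

The estimated step is a 1.4-fold lower number from compound 2 to compound 3 (0.15 log units; within the scatter). For compound 3 the expected value is 16000 nM, with an estimated range of 5000 nM to 45000 nM.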

Compound 3, concentration for 50% growth inhibition: > 100000 nM
Compound 3: only a limit was reported; the forecaster's own chance of this, stated with the estimate: 5%; at least 6.2-fold (0.79 log units) between middle value and limit.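

In this assay, compound 3 gives > 100000 nM, which is a limit of the assay and not a number. The earlier compounds shown here showed no sensitivity at this aromatic carbon, para to a large group, with hydroxy in place of fluoro giving only a 1.8-fold higher number from compound 1 to compound 2 (0.24 log units; within the scatter), but the position does respond to the group it carries: dimethylamino in place of hydroxy gives an at least 4.4-fold higher number from compound 2 to compound 3 (0.64 log units; beyond the scatter), and dimethylamino in place of fluoro gives an at least 7.7-fold higher number from compound 1 to compound 3 (0.88 log units; beyond the scatter). Both new steps lie beyond the scatter, and each has only a lower bound on its size: the limit of > 100000 nM in this assay, at which 1 of the 3 values shown sits.

The change from hydroxy to dimethylamino alters both the heavy-atom count, from 1 to 3, and the hydrogen-bond donor count, from 1 to 0, so these compounds cannot show which difference goes with the result. A plain amino group or a methoxy group at the same place would separate the two, since the amino group keeps a nitrogen without the two methyl groups and the methoxy group carries oxygen with one added carbon.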